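Deoxyuridine Series: Octyl Replacing tert-Butylphenyl on the Oxazole Ring

The source may hold more compounds than are shown below. What is called first, only, known or untested is meant among the compounds shown, and "the series" means these compounds.

Of the compounds shown here, two on the shared core have been measured. Compound 1 `CC(C)(C)c1ccc(-c2cc(-c3cn([C@H]4C[C@H](O)[C@@H](CO)O4)c(=O)[nH]c3=O)on2)cc1` gives 98.9% in a functional assay on NCI-H23 cells (Homo sapiens) for cytotoxicity, read by sulforhodamine B assay, tested at 10 uM; on this read-out lower numbers stand for less inhibition and higher numbers for more inhibition at the one concentration tested (going by the name of the read-out). Compound 2 `O=c1[nH]c(=O)n([C@H]2C[C@H](O)[C@@H](CO)O2)cc1-c1cn(Cc2ccccc2)nn1` gives 97.5% in this assay; the two values differ by an amount within the usual scatter, so the numbers of compound 1 and compound 2 are level, and no order between them can be stated. Among the measured compounds shown here, no step between measured compounds that differ in one place is known.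

Compound 3 `CCCCCCCCc1cc(-c2cn([C@H]3C[C@H](O)[C@@H](CO)O3)c(=O)[nH]c2=O)on1` is not yet measured. It differs from compound 1 by octyl in place of 4-(tert-butyl)phenyl on an aromatic carbon. For the measured compounds named here, nothing measured so far shows a change at this position, and both measured compounds sit near the top of the read-out. For compound 3 the step of a number 10.9 percentage points lower from compound 1 to compound 3 (beyond the scatter) is expected to be small, if any, in the downward direction only because compound 1 already gives 98.9% and the read-out cannot rise much above it. Compound 3 is therefore estimated at 88%, with a plausible range from 55% to 100%.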

Compound 3, a percentage reported as inhibition, at one concentration (the size of the read-out at that concentration, not a potency): 120%
Beside the measured number, compound 3's estimate is 32 percentage points below it, and the stated range ends below it.
By their numbers in this assay, from the lowest: compounds 2 and 1 (each within the scatter of the next); then compound 3.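

The position on the aromatic carbon next to the ring nitrogen is the first in the series shown to respond to a change: octyl in place of 4-(tert-butyl)phenyl gives a number 21.1 percentage points higher from compound 1 to compound 3 (beyond the scatter) in this assay. An aromatic ring at this position is thus not required for a high read-out, and compound 3, at 120% in this assay, shows that compound 1 did not mark the upper end of this read-out. No evidence is available on what lies behind this step.

A single pair cannot separate the effect of chain length from that of losing the phenyl ring, and butyl or dodecyl at the same place would bear on this. Also open, on these data alone, is whether a terminal amine or carboxylic acid on the octyl chain would keep the read-out at this level.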